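The source may hold more compounds than are shown below. What is called first, only, known or untested is meant among the compounds shown, and "the series" means these compounds.

Compound 1, `Fc1cccc(-c2nc(Nc3ccccc3)c3ccccc3n2)c1`: in a functional assay on HT29-AK cells (Homo sapiens) for cytotoxicity, read by MTT assay, with a stated time of 48 h (a higher number here means a weaker inhibitor, a lower number a stronger inhibitor), compound 1 gives > 50000 nM, a limit of the assay.
Compound 2, `Fc1ccc2nc(-c3ccccc3)nc(Nc3ccccc3)c2c1`: in this assay compound 2 gives > 50000 nM, also a limit.
Compound 3, `Fc1cccc(Nc2nc(-c3cccc(F)c3)nc3ccc(F)cc23)c1`: in this assay compound 3 gives > 50000 nM, again a limit.

Compound 3 therefore stands nowhere that can be ordered: its value is a limit, and the other two values shown are limits as well, so none of the three can be called stronger or weaker than another. This is summed up by the limit of > 50000 nM in this assay, at which 3 of the 3 values shown sit.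

Compound 4, `Fc1cccc(-c2nc(Nc3cccc(Cl)c3)c3cc(F)ccc3n2)c1`, has not yet been measured in this assay. It differs from compound 3 in one place: chloro in place of fluoro on an aromatic carbon. For the measured compounds named here, no measured pair in this set shows the effect of such a change, so there is no step to lean on. Since the measured values all sit at the limit (the limit of > 50000 nM in this assay, at which 3 of the 3 values shown sit), the expectation is that compound 4 will also fall at or near that limit, with a step from compound 3 to compound 4 expected to be a step that the limit leaves unreadable from compound 3 to compound 4, that is, nothing clearly beyond the scatter. Compound 4 is thus expected at about 60000 nM, with a range from 10000 nM to 200000 nM.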

Compound 4, half-maximal inhibitory concentration: > 50000 nM
Compound 4 ended at the assay's limit; the forecaster's own chance of this, stated with the estimate: 75%; the middle value is on the limit's open side.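

Compound 3 and compound 4 both end at a limit of the assay, so no step can be read between them: the limit of > 50000 nM in this assay, at which 4 of the 4 values shown sit.

The compounds shown leave open whether chloro in place of fluoro on an aromatic carbon changes anything in this assay, as none gives an orderable value.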